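Swapping an Oxane for a Pyridinylmethyl Carbamate

The source may report more compounds than this note shows. Statements on the series, on what has been measured and on what is new or still open speak of the compounds shown alone.

Compound 1 `Cc1cc(NC(=O)C2CCCO2)nn1Cc1cc(Cl)ccc1OCc1ccccc1` and compound 2 `Cc1cc(NC(=O)C2CCOCC2)nn1Cc1cc(Cl)ccc1OCc1ccccc1` share one core and differ only on the carbonyl carbon. In a physicochemical assay for lipophilicity, at pH 7.4 (on this read-out higher numbers stand for higher lipophilicity and lower numbers for lower lipophilicity), compound 1 gives > 3.7, which is a limit of the assay rather than a number. In this assay compound 2 likewise gives > 3.7, again a limit and not a number. Both values sit at the limit of > 3.7 in this assay, at which 2 of the 2 values shown sit, so the step that the two limits leave unreadable from compound 1 to compound 2 cannot be read in size or direction. Compound 3 `Cc1cc(NC(=O)OCc2ccccn2)nn1Cc1cc(Cl)ccc1OCc1ccccc1` has not yet been measured; it differs from compound 2 by (pyridin-2-yl)methoxy in place of oxan-4-yl on a carbonyl carbon. Within the data shown here, the only measured step bears on this change in the sense that it shows how the core with such groups tends to exceed the readable range, and nothing more. The step from compound 2 to compound 3 is therefore expected to be a step that the limit leaves unreadable from compound 2 to compound 3, with the true size unknown. Compound 3 is estimated at 4.1, in a range from 3.5 to 4.7, and most likely this assay will again report only a limit for it.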

Compound 3, distribution coefficient: 3.1
Compound 3: middle estimate off by 1.00 log units, on the high side; measured number outside the range, below it.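

On the carbonyl carbon, (pyridin-2-yl)methoxy in place of oxan-4-yl gives a number at least 0.60 log units lower from compound 2 to compound 3 (beyond the scatter), and the same group in place of oxolan-2-yl gives a number at least 0.60 log units lower from compound 1 to compound 3 (beyond the scatter). This position can therefore bring the shared core into the readable range of this assay, where compound 3 gives 3.1. Compound 1 and compound 2 remain limits rather than numbers: the limit of > 3.7 in this assay, at which 2 of the 3 values shown sit.

As far as these compounds go, the true size of both new steps stays unknown, and the step between compound 1 and compound 2 still cannot be read. From the compounds shown here alone, the change also replaces the ring and the link to the carbonyl carbon at once, so it remains open how a phenylmethoxy group, which has no ring nitrogen, would read at this place.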